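Extending the chain toward the dichlorophenoxy end

The source may report more compounds than this note shows. Statements on the series, on what has been measured and on what is new or still open speak of the compounds shown alone.

The measured compounds:
compound 1 `COc1ccc(OCCCCCN2CCCC(COC(=O)c3ccccc3N3C(=O)CC(C)C3=O)C2)cc1` gives 14500 nM in an in vitro functional assay on HEK ts201 cells for antagonist activity at Neuronal acetylcholine receptor; alpha4/beta2 (Homo sapiens), read by fluorescence and calcium flux; on this read-out higher numbers stand for weaker inhibition and lower numbers for stronger inhibition
compound 2 `CC1CC(=O)N(c2ccccc2C(=O)OCC2CCCN(CCCCCCc3ccccc3)C2)C1=O` gives 29500 nM
compound 3 `CC1CC(=O)N(c2ccccc2C(=O)OCC2CCCN(CCCCOc3ccc(Cl)c(Cl)c3)C2)C1=O` gives 12300 nM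

Compound 3 holds the lowest of the three numbers, but its separation from compound 1 is within the scatter (a 1.2-fold lower number from compound 1 to compound 3 (0.07 log units; within the scatter)), so the two cannot be ordered. Only compound 2 stands clearly apart from it: a 2.4-fold lower number from compound 2 to compound 3 (0.38 log units; beyond the scatter).

Compound 4 `CC1CC(=O)N(c2ccccc2C(=O)OCC2CCCN(CCCCCOc3ccc(Cl)c(Cl)c3)C2)C1=O` differs from compound 3 in one place: (3,4-dichlorophenoxy)methyl in place of 3,4-dichlorophenoxy on a saturated chain carbon, four bonds along the chain from an amine nitrogen in a ring. For the measured compounds named here, no measured step repeats this change on its own. The nearest is the step from compound 1 to compound 3, which swapped a longer chain bearing one aryl group for a shorter chain bearing another, and the number barely moved: a 1.2-fold lower number from compound 1 to compound 3 (0.07 log units; within the scatter). The step from compound 1 to compound 2 also altered the chain together with its terminal group, and it was modest: a 2.0-fold higher number from compound 1 to compound 2 (0.31 log units; beyond the scatter). Neither step separates chain length from the change of aryl group, so the data offer no firm lead on a pure extension by one carbon. Compound 4 is therefore expected to stay near compound 3, with an estimated step of a 1.1-fold lower number from compound 3 to compound 4 (0.05 log units; within the scatter). Compound 4 is estimated at 11000 nM, with a range from 5000 nM to 25000 nM.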

Compound 4, half-maximal inhibitory concentration: 17400 nM
Estimate against measurement, compound 4: 1.6-fold (0.20 log units) below; the range from low to high includes it.
By their numbers in this assay, from the lowest: compounds 3, 1, 4 and 2 (each within the scatter of the next, the first and the last beyond it).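

For the compounds shown here, compound 4 gives the first reading of (3,4-dichlorophenoxy)methyl in place of 3,4-dichlorophenoxy alone, on a saturated chain carbon, four bonds along the chain from an amine nitrogen in a ring, and in this assay this change cannot be told from no change (a 1.4-fold higher number from compound 3 to compound 4 (0.15 log units; within the scatter)). With the chain held constant, 3,4-dichlorophenyl in place of 4-methoxyphenyl on an oxygen on a saturated carbon is equally unresolved (a 1.2-fold higher number from compound 1 to compound 4 (0.08 log units; within the scatter)), so neither the chain extension nor this aryl exchange, taken alone, registers on this read-out. Compound 3 stands clear of compound 2, but compound 4 does not (a 1.7-fold lower number from compound 2 to compound 4 (0.23 log units; within the scatter)), which leaves the separation between those two chains resting on a single pair. No supporting data are available that could account for these numbers.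

The compounds shown leave open whether a longer chain or a shorter one, with the 3,4-dichlorophenoxy end kept, would stand clear of compound 3. They also leave open whether an amine or a carboxylic acid on the aryl ring, in place of the chlorines, would move the number beyond the scatter.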